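Cyclopentyl in Place of Butyl: an Expected Inhibition Value

This account rests on a few compounds, and the source may have more. Where it says the series, first, only, none or still open, it means among the compounds named here.

Measured compounds:
Compound 1 `COC(CCn1cnc2c(NCc3ccc(C(=O)Nc4ccccc4N)cc3)nc(Cl)nc21)OC` gives 34.2% in a functional assay on HepG2 cells (Homo sapiens) for antiproliferative activity, read by CCK-8 assay, with a stated time of 72 h, tested at 8 uM; a lower number here means a weaker effect, a higher number a stronger effect of the compound at the concentration tested.
Compound 2 `CCCCn1cnc2c(Nc3cccc(Cl)c3)nc(NCOCc3ccc(/C=C/C(=O)Nc4ccccc4N)cc3)nc21` gives 30.4% in this assay.
Compound 3 `CC1CCN(c2nc(Cl)nc3c2ncn3Cc2ccc(/C=C/C(=O)Nc3ccccc3N)cc2)CC1` gives 32.2% in this assay.

All three numbers sit close together. The value of compound 2 lies within the usual scatter of the value of compound 3 and within the scatter of the value of compound 1 as well, so the three measured compounds cannot be told apart in this assay on these data. Among the measured compounds shown here, no pair among them differs in only one place, so no single structural step has a measured size here.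

Compound 4 `Nc1ccccc1NC(=O)/C=C/c1ccc(COCNc2nc(Nc3cccc(Cl)c3)c3ncn(C4CCCC4)c3n2)cc1` has not yet been measured. It differs from compound 2 in one place: cyclopentyl in place of butyl on an aromatic nitrogen. The rest of the molecule is unchanged.

For the measured compounds named here, with no comparable step measured, a change of this kind is expected to stay within the scatter, with no clear direction. The step from compound 2 to compound 4 is therefore expected to be small, a number 2.6 percentage points higher from compound 2 to compound 4 (within the scatter). In this assay compound 4 is estimated at 33%, with a range from 20% to 46%.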

Compound 4, a percentage reported as inhibition, at one concentration (the size of the read-out at that concentration, not a potency): 14.8%
Compound 4: middle estimate off by 18.2 percentage points, on the high side; measured number outside the range, below it.
By their numbers in this assay, from the lowest: compound 4; then compounds 2, 3 and 1 (each within the scatter of the next).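

In this assay, cyclopentyl in place of butyl on the aromatic nitrogen gives a number 15.6 percentage points lower from compound 2 to compound 4 (beyond the scatter), the first single-place step available in this set, and it shows that the group at this position can change the read-out. Among the compounds shown here, the earlier compounds could not show this, since no two of them differ in only one place and their values all lie within the scatter of one another. No measurement at hand bears on what lies behind this step.

For the compounds shown here, the one pair leaves open whether the ring itself or the change from butyl to a larger carbon group goes with the lower number, a question that a pentyl chain or a cyclobutyl group on the same nitrogen could address. It also leaves open how a group carrying an amine or a carboxylic acid at this position would read in this assay.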